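Removing the methoxy from compound 1

This account rests on a few compounds, and the source may have more. Where it says the series, first, only, none or still open, it means among the compounds named here.

- compound 1 `CON[C@]1(CCC(C)C)C(=O)C(C2=NS(=O)(=O)c3cc(NS(C)(=O)=O)ccc3N2)=C(O)c2ccccc21`: 34.1%
- compound 2 `CC(C)(C)CCC1(NCc2ccc3ccccc3c2)C(=O)C(C2=NS(=O)(=O)c3cc(NS(C)(=O)=O)ccc3N2)=C(O)c2ccccc21`: 28.1%
- compound 3 `COc1ccccc1CNC1(CCC(C)(C)C)C(=O)C(C2=NS(=O)(=O)c3cc(NS(C)(=O)=O)ccc3N2)=C(O)c2ccccc21`: 48%

These values come from an in vivo ADME assay on the whole organism (strain Sprague-Dawley) for pharmacokinetics, with Rattus norvegicus as the target, at a dose of 5 mg/kg by the oral route; on this read-out lower numbers stand for lower oral bioavailability and higher numbers for higher oral bioavailability. Compound 1 at 34.1% cannot be told apart from compound 2 at 28.1%. Compound 3 gives 48%, and its gap to compound 1 exceeds the usual scatter.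

The next compound is compound 4 `CC(C)CC[C@@]1(N)C(=O)C(C2=NS(=O)(=O)c3cc(NS(C)(=O)=O)ccc3N2)=C(O)c2ccccc21`, which carries hydrogen in place of methoxy on an amine nitrogen.

Among the compounds with values here, only one measured step exists: a number 19.9 percentage points higher from compound 2 to compound 3 (beyond the scatter). That step swaps a different group at a different place, so it does not test this change directly. Within the data shown here, no measured pair shows what losing the methoxy does. The step therefore gives no direction, and serves only as a guide to how far a single change can move this assay. The best expectation is no shift beyond the scatter, with a wide margin either way. The expected step is a number 0.9 percentage points higher from compound 1 to compound 4 (within the scatter). Compound 4 is estimated at 35%, with an expected range of 17% to 53%.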

Compound 4, oral bioavailability: 0%
Compound 4: middle estimate off by 35 percentage points, on the high side, outside the stated range (below it).
By their numbers in this assay, from the lowest: compound 4; then compounds 2 and 1 (each within the scatter of the next); then compound 3.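

Taking just the methoxy off this amine nitrogen, a loss of 2 heavy atoms, gives a number 34.1 percentage points lower from compound 1 to compound 4 (beyond the scatter) in this assay, so a very small edit at this position can have a large effect. Compounds 1, 2 and 3 all carry a group on this nitrogen, and compound 4 is the first shown with a plain amino group, at 0%. No measurement shown here explains the drop in oral bioavailability.

Open, as far as these compounds go, is whether the oxygen of the methoxy matters or whether any small group on the nitrogen would do, which a methyl, giving methylamino, or an ethoxy at the same place would help to separate. Also open, from the compounds shown here alone, is whether the plain amino group would give the same result alongside a different chain on the core.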